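The source may hold more compounds than are shown below. What is called first, only, known or untested is meant among the compounds shown, and "the series" means these compounds.

Measured so far, in a functional assay on the whole organism (strain Wister albino) for inhibition, with Rattus norvegicus as the target, read by paw edema, with a stated time of 1 h, at a dose of 50 mg/kg by the intraperitoneal route; a higher number here means more inhibition at the dose given (going by the name of the read-out), a lower number less inhibition:

compound 1, `CCOC(=O)c1c(-c2ccc(Cl)cc2)cc(-c2ccccc2)nc1N1CCN(C)CC1` — 65.8%
compound 2, `CCOC(=O)c1c(-c2ccc(Cl)cc2)cc(-c2ccccc2)nc1Nc1ccccc1` — 62.3%
compound 3, `CCOC(=O)c1c(-c2ccc(Cl)cc2)cc(-c2ccccc2)nc1Nc1ccc(OC)cc1` — 33.3%

Compound 3 stands lowest of the three numbers. The step of a number 29 percentage points lower from compound 2 to compound 3 (beyond the scatter) separates it clearly from compound 2, and the step of a number 32.5 percentage points lower from compound 1 to compound 3 (beyond the scatter) from compound 1, while compound 1 and compound 2 lie within the scatter of each other, as a number 3.5 percentage points lower from compound 1 to compound 2 (within the scatter) shows.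

Compound 4 is `CCOC(=O)c1c(-c2ccc(Cl)cc2)cc(-c2ccccc2)nc1Nc1ccc(Cl)cc1`. It differs from compound 3 in one place: chloro in place of methoxy on an aromatic carbon

For the measured compounds named here, only one measured step bears on this change, and only indirectly: a number 29 percentage points lower from compound 2 to compound 3 (beyond the scatter) shows that putting methoxy onto that ring in place of hydrogen lowered the number by a modest but clear amount. Going by the values given here, no measured pair shows chloro against methoxy or chloro against hydrogen on this ring, so the direction of the coming step cannot be read from the data alone. From the compounds shown here alone, removing the methoxy that went with the fall from compound 2 to compound 3 gives some ground to expect that compound 4 returns part of the way toward compound 2, but the chloro that replaces it is untested. The expected step is a number 14.7 percentage points higher from compound 3 to compound 4 (beyond the scatter), upward but uncertain. Compound 4 is therefore estimated at 48%, between 28% and 68%.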

Compound 4, a percentage reported as inhibition, in the whole organism at one dose (the size of the read-out at that dose, not a potency): 44.6%
For compound 4 the middle estimate is 3.4 percentage points above the measured one, and the stated range covers the measured number.
By their numbers in this assay, from the lowest: compound 3; then compound 4; then compounds 2 and 1 (each within the scatter of the next).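

In this assay, this position on the anilino ring now has two measured substituents. Chloro in place of hydrogen gives a number 17.7 percentage points lower from compound 2 to compound 4 (beyond the scatter) and chloro in place of methoxy gives a number 11.3 percentage points higher from compound 3 to compound 4 (beyond the scatter), so the unsubstituted ring of compound 2 stands above both substituted rings, and the choice of substituent also matters. The (4-chlorophenyl)amino group in place of 4-methylpiperazin-1-yl gives a number 21.2 percentage points lower from compound 1 to compound 4 (beyond the scatter), so like the (4-methoxyphenyl)amino group it falls clearly short of the piperazine. No measurement here explains why these groups differ.

From the compounds shown here alone, it remains open whether a smaller atom such as fluoro, or a hydroxyl or a carboxylic acid, at this place on the ring would match the unsubstituted ring. Going by these compounds, it is also open whether a morpholine in place of the methylpiperazine would hold the number of compound 1.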